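A few compounds are considered here, and "the series" means these few. Any claim that something is new, unique, unknown or untested is made for them only; others in the source may bear on it.

Series notes. The shared core of compound 3 `Cc1ccc(-c2cc(/N=C/N(C)C)n(-c3cccc(Cl)c3)n2)cc1` carries a 3-chlorophenyl group and a 4-methylphenyl group. In a functional assay on Jurkat cells (Homo sapiens) for inhibition, read by MTT assay, with a stated time of 72 h (on this read-out lower numbers stand for stronger inhibition of growth and higher numbers for weaker inhibition of growth), compound 3 gives a limit of the assay, > 100000 nM. Compound 1 `Cc1ccc(-c2cc(N)n(-c3cccc(Cl)c3)n2)cc1` differs from it by one nitrogen atom in place of a group of 5 heavy atoms (3 carbon, 2 nitrogen; no ring), on an aromatic carbon; in this assay compound 1 gives 56600 nM, so the step runs an at least 1.7-fold lower number from compound 3 to compound 1 (0.24 log units; that floor lies within the scatter). Going by these compounds, the size of that step is capped by the limit of > 100000 nM in this assay, at which 1 of the 3 values shown sits, so its true extent stays open. Compound 2 `CN(C)/C=N/c1c(C=O)c(-c2ccccc2)nn1-c1ccccc1` sits on a different core; the difference between the two cores is not broken down here. In this assay compound 2 gives 23500 nM, the lowest of the numbers that were read. Compound 4 `Nc1c(C=O)c(-c2ccccc2)nn1-c1ccccc1` is not yet measured; it differs from compound 2 by one nitrogen atom in place of a group of 5 heavy atoms (3 carbon, 2 nitrogen; no ring), on an aromatic carbon. This is the same kind of change as that from compound 3 to compound 1, but the surroundings differ: in compound 2 the aromatic carbon lies next to the ring atom that bears a formyl group and next to the ring atom that bears a phenyl group, and two ring bonds from the ring atom that bears a phenyl group, whereas in compound 3 it lies next to the ring atom that bears a 3-chlorophenyl group and two ring bonds from the ring atom that bears a 4-methylphenyl group. The step from compound 2 to compound 4 in this assay is estimated at a 1.6-fold lower number from compound 2 to compound 4 (0.19 log units; within the scatter), beside an at least 1.7-fold lower number from compound 3 to compound 1 (0.24 log units; that floor lies within the scatter) from the earlier pair; this rests on that single pair, whose size is only a floor. It also rests on compound 2 at 23500 nM leaving room downward. Compound 4 is expected to give 15000 nM, within 5000 nM to 45000 nM.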

Compound 4, concentration for 50% growth inhibition: 87300 nM
Compound 4: the middle estimate sits 5.8-fold (0.76 log units) below what was measured; measured number above the stated range.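

In this assay, exchanging the group on the aromatic carbon for amino on the core of compound 2 gives a 3.7-fold higher number from compound 2 to compound 4 (0.57 log units; beyond the scatter), so the change does not carry over unaltered from the core of compound 3 to the core of compound 2: the same change on two cores in this assay, an at least 1.7-fold lower number (0.24 log units; that floor lies within the scatter) from compound 3 to compound 1 and a 3.7-fold higher number (0.57 log units; beyond the scatter) from compound 2 to compound 4, at least 6.5-fold (0.81 log units) apart, beyond the scatter of two such steps

Compound 3 gives > 100000 nM, which is a limit of the assay, so the full size of the earlier step stays open: the limit of > 100000 nM in this assay, at which 1 of the 4 values shown sits.

The two pairs show that the outcome of this change depends on the core within these compounds, but they do not show which difference between the cores is responsible, and one pair per core sets no rule for any further core.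

Open, going by these compounds, is how the same step would run on the core of compound 2 with a nitrile or a carboxylic acid in place of the formyl group, which would test whether the formyl group goes with the direction seen in that pair. Also open, on these data alone, is how a methylamino group on the same aromatic carbon would read on each core, as a case that stands between amino and the larger group that leaves.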